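A few compounds are considered here, and "the series" means these few. Any claim that something is new, unique, unknown or untested is made for them only; others in the source may bear on it.

Of the compounds shown here, three built on the shared core have been tested in a functional assay on BV-2 cells (Mus musculus) for inhibition, read by ELISA, with a stated time of 16 h; a lower number here means a stronger inhibitor, a higher number a weaker inhibitor. Compound 1 `Cc1ccnnc1N1CCN(c2ncccn2)CC1` carries a hydrogen on an aromatic carbon of that core; in this assay compound 1 gives > 100000 nM, which is a limit of the assay rather than a number. Compound 2 `Cc1cc(C(C)C)nnc1N1CCN(c2ncccn2)CC1` carries an isopropyl group on that aromatic carbon, and in this assay compound 2 gives > 100000 nM, again a limit. Within the data shown here, compound 3 `Cc1cc(-c2ccc(F)cc2)nnc1N1CCN(c2ncccn2)CC1` carries a 4-fluorophenyl group there, and in this assay compound 3 gives 76300 nM, the only actual number among the three. The step from compound 1 to compound 3 is an at least 1.3-fold lower number from compound 1 to compound 3 (0.11 log units; that floor lies within the scatter), and the step from compound 2 to compound 3 is an at least 1.3-fold lower number from compound 2 to compound 3 (0.11 log units; that floor lies within the scatter); both rest on (the limit of > 100000 nM in this assay, at which 2 of the 3 values shown sit), so their true size cannot be read. The step from compound 1 to compound 2 is a step that the two limits leave unreadable from compound 1 to compound 2.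

Compound 4 `COc1ccc(-c2cc(C)c(N3CCN(c4ncccn4)CC3)nn2)cc1` differs from compound 3 in a single place: methoxy in place of fluoro on an aromatic carbon. Among the measured compounds shown here, none of the measured steps touches the 4-fluorophenyl group itself, so no measured step bears directly on this change. Compound 4 is therefore expected to stay close to compound 3, with a step of a 1.3-fold lower number from compound 3 to compound 4 (0.10 log units; within the scatter) that lies within the scatter. The estimate for compound 4 in this assay is 60000 nM, with a range of 20000 nM to 150000 nM.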

Compound 4, half-maximal inhibitory concentration: 5200 nM
Compound 4: the middle estimate sits 12-fold (1.06 log units) above what was measured, and the stated range ends above it.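

In this assay, the group on the six-membered aromatic ring of carbon only, para to a large group, turns out to matter a great deal: methoxy in place of fluoro gives a 15-fold lower number from compound 3 to compound 4 (1.17 log units; beyond the scatter). The earlier compounds shown here offered only a hint that an aromatic group at this place on the shared core might help, and that hint lay within the scatter; with a 4-methoxyphenyl group the difference becomes clear, with an at least 19-fold lower number from compound 1 to compound 4 (1.28 log units; beyond the scatter) and an at least 19-fold lower number from compound 2 to compound 4 (1.28 log units; beyond the scatter). These last two steps are only floors that rest on a limit of the assay, and their true size cannot be read: the limit of > 100000 nM in this assay, at which 2 of the 4 values shown sit.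

The compounds shown leave open whether the oxygen or the added carbon of the methoxy group carries the step, a question that a hydroxy group or an ethyl group at the same place would help to separate. They also leave open whether a longer chain such as ethoxy, an amine or a carboxylic acid there would lower the number further or raise it again.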